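The source may report more compounds than this note shows. Statements on the series, on what has been measured and on what is new or still open speak of the compounds shown alone.

Compound 1 `CCCOC(=O)C1=C(C)NC(=S)NC1c1ccco1` gives 1% in an assay on membranes from CHO cells for displacement of a labelled ligand from adenosine receptor A1 (Homo sapiens), read by scintillation counting, with a stated time of 60 min, tested at 1 uM; on this read-out higher numbers stand for more inhibition at the one concentration tested (going by the name of the read-out) and lower numbers for less inhibition. Compound 2 `CC1=C(C(=O)OC(C)(C)C)C(c2ccco2)NC(=S)N1` gives 3% in this assay, so that a number 2 percentage points higher from compound 1 to compound 2 (within the scatter). Compound 3 `CCCOC(=O)C1=C(C)NC(=S)NC1c1ccoc1` gives 4% in this assay, where a number 3 percentage points higher from compound 1 to compound 3 (within the scatter). On these numbers compound 3 stands at the top of the three, but its gaps to compound 2 and to compound 1 both lie within the scatter, so the three cannot be told apart.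

Compound 4 `CC1=C(C(=O)OC(C)(C)C)C(c2ccoc2)NC(=S)N1` has not yet been measured. Relative to compound 3 the change is tert-butyl in place of propyl on an oxygen next to a carbonyl group. Within the data shown here, the one measured step that bears on this change is a number 2 percentage points higher from compound 1 to compound 2 (within the scatter), which lay within the scatter, so in this assay no step beyond the scatter is expected here. Compound 4 is estimated at 5%, in a range from 0% to 12%. The expected step is thus a number 1 percentage points higher from compound 3 to compound 4 (within the scatter).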

Compound 4, a percentage reported as inhibition, at one concentration (the size of the read-out at that concentration, not a potency): 18%
Compound 4: the middle estimate sits 13 percentage points below what was measured; measured number above the stated range.
By their numbers in this assay, from the lowest: compounds 1, 2 and 3 (each within the scatter of the next); then compound 4.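

Among these compounds, with tert-butyl in place of propyl on an oxygen next to a carbonyl group, a number 14 percentage points higher from compound 3 to compound 4 (beyond the scatter) in this assay is the first step of this change beyond the scatter, and furan-3-yl in place of furan-2-yl likewise gives a number 15 percentage points higher from compound 2 to compound 4 (beyond the scatter). So far only compound 4, which carries both changes, stands clear of the other compounds, yet the tert-butyl change cannot be called dependent on the core: the same change on two cores in this assay, a number 2 percentage points higher (within the scatter) from compound 1 to compound 2 and a number 14 percentage points higher (beyond the scatter) from compound 3 to compound 4, 12 percentage points apart, within the scatter of two such steps. The furan change reads the same way: the same change on two cores in this assay, a number 3 percentage points higher (within the scatter) from compound 1 to compound 3 and a number 15 percentage points higher (beyond the scatter) from compound 2 to compound 4, 12 percentage points apart, within the scatter of two such steps.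

As far as these compounds go, whether a longer chain or a benzyl group on that oxygen would keep the number of compound 4 stays open. So does the outcome of a phenyl group in place of the furan-3-yl.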